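Gem-dimethyl on the acetic acid arm of compound 3

The compounds below may be only part of what the source reports. "The series", "measured", "known", "first", "only" and "open" are said of these compounds alone.

Measured so far:
compound 1 `Cc1ccc(CC(=O)O)cc1NC(=O)c1cc(C)c(OC[C@@H]2CN(C)c3ccccc3O2)cc1C` gives 2600 nM
compound 2 `Cc1cc(OC[C@@H]2CN(C)c3ccccc3O2)ccc1C(=O)Nc1cc(CC(=O)O)ccc1Cl` gives 1800 nM
compound 3 `Cc1cc(C(=O)Nc2cc(CC(=O)O)ccc2Cl)c(C)cc1OC[C@@H]1CN(C)c2ccccc2O1` gives 1800 nM

The three compounds were tested in an assay on CHO cells for displacement of a labelled ligand from prostacyclin receptor (Homo sapiens), read by scintillation counting, with a stated time of 30 min; a lower number here means a stronger inhibitor, a higher number a weaker inhibitor. Compound 3 stands level with compound 2 at the digits given, and the two of them together hold the lowest numbers of the three; the step of a 1.4-fold lower number from compound 1 to compound 3 (0.16 log units; within the scatter) and the step of no change at the digits printed from compound 2 to compound 3 (within the scatter) are both within the scatter, so none of the three can be set apart from the others.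

Compound 4 `Cc1cc(C(=O)Nc2cc(C(C)(C)C(=O)O)ccc2Cl)c(C)cc1OC[C@@H]1CN(C)c2ccccc2O1` carries the change (1-carboxy-1-methylethyl in place of carboxymethyl on an aromatic carbon), in the words of the place description meta to a large group and para to a chloro group. Neither measured step touches this part of the molecule: both concern substituents on the aromatic rings, and the step of a 1.4-fold lower number from compound 1 to compound 3 (0.16 log units; within the scatter) and the step of no change at the digits printed from compound 2 to compound 3 (within the scatter) were small. Going by the values given here, no measured step therefore bears directly on it, and the expectation rests on the absence of any large movement among the three compounds. Compound 4 is expected to show a step of no change at the digits printed from compound 3 to compound 4 (within the scatter), with an estimate of 1800 nM and a range from 600 nM to 5400 nM.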

Compound 4, inhibition constant: 3300 nM
Compound 4: middle estimate off by 1.8-fold (0.26 log units), on the low side; low and high end bracket the measured number.
By their numbers in this assay, from the lowest: compounds 2, 3, 1 and 4 (each within the scatter of the next).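

In this assay, the step to 1-carboxy-1-methylethyl in place of carboxymethyl, on the aromatic carbon para to a chloro group, is a 1.8-fold higher number from compound 3 to compound 4 (0.26 log units; within the scatter). Going by these compounds alone, compound 1, compound 2 and compound 3 differ only in substituents on the aromatic rings and all carry the carboxymethyl arm, so this is the first reading on the arm itself, and it shows that this larger group leaves the number within the scatter of compound 3. No measurement shown offers an explanation for this result.

The compounds shown leave open how the number would respond if the carboxylic acid were replaced by a primary amide or a tetrazole, or if a longer chain, such as 2-carboxyethyl, stood at this carbon. They also leave open whether 1-carboxy-1-methylethyl would give a similar step with the ring substituents of compound 1 or compound 2.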